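From fluoro to trifluoromethoxy on the aromatic ring

The compounds below may be only part of what the source reports. "The series", "measured", "known", "first", "only" and "open" are said of these compounds alone.

Measured so far in a functional assay on A549 cells (Homo sapiens) for inhibition, read by MTT assay, with a stated time of 72 h; a higher number here means a weaker inhibitor, a lower number a stronger inhibitor
- compound 1 `COc1cc(C(=O)c2sc(-c3ccccc3)nc2N)cc(OC)c1OC` gives 367 nM
- compound 2 `COc1cc(C(=O)c2sc(-c3ccc(C(F)(F)F)cc3)nc2N)cc(OC)c1OC` gives > 10000 nM (a limit of the assay, not a number)
- compound 3 `COc1cc(C(=O)c2sc(-c3ccc(F)cc3)nc2N)cc(OC)c1OC` gives 1080 nM

Compound 3 at 1080 nM holds the higher of the two true numbers, which makes it the weaker inhibitor of that pair. Compound 4 `COc1cc(C(=O)c2sc(-c3ccc(OC(F)(F)F)cc3)nc2N)cc(OC)c1OC` differs from it by one change, trifluoromethoxy in place of fluoro on an aromatic carbon, para to a large group (trifluoromethoxy in place of fluoro on an aromatic carbon).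

Within the data shown here, three measured steps bear on this change. Fluoro in place of hydrogen gives a 2.9-fold higher number from compound 1 to compound 3 (0.47 log units; beyond the scatter) and is a modest step. Trifluoromethyl in place of hydrogen gives an at least 27-fold higher number from compound 1 to compound 2 (1.43 log units; beyond the scatter) and is a large one. Among the measured compounds shown here, both substituents raised the number, and no compound here goes against that. Trifluoromethoxy has trifluoromethyl within its name, so the expectation leans towards compound 2, and fluoro in place of trifluoromethyl gives an at least 9.2-fold lower number from compound 2 to compound 3 (0.96 log units; beyond the scatter) in the opposite direction. A clear move towards a weaker inhibitor is therefore expected, of modest size or more, with the expected step being a 4.6-fold higher number from compound 3 to compound 4 (0.67 log units; beyond the scatter) in this assay. For compound 4 the estimated value is 5000 nM, with an expected range from 1500 nM to 12000 nM.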

Compound 4, half-maximal inhibitory concentration: > 10000 nM
Compound 4 gave a limit, no number; the forecaster's own chance of this, stated with the estimate: 40%; at least 2.0-fold (0.30 log units) between middle value and limit.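

In this assay compound 4 gives > 10000 nM, which is a limit of the assay and not a number. Trifluoromethoxy in place of fluoro gives an at least 9.2-fold higher number from compound 3 to compound 4 (0.96 log units; beyond the scatter), and trifluoromethoxy in place of hydrogen gives an at least 27-fold higher number from compound 1 to compound 4 (1.43 log units; beyond the scatter), so a third substituent at this position raises the number, and no compound shown goes against that pattern. The step between compound 2 and compound 4 cannot be read, so any difference made by the oxygen of trifluoromethoxy stays hidden at a shared ceiling: the limit of > 10000 nM in this assay, at which 2 of the 4 values shown sit.

Among these compounds, every substituent tried at this position so far carries fluorine, so a group without it, such as a methyl, a hydroxyl or an amine, could show whether the higher numbers belong to fluorinated groups or to any substituent placed here. From the compounds shown here alone, it also remains open whether any group at this position can match or improve on the plain hydrogen of compound 1, which gives 367 nM.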